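The source may hold more compounds than are shown below. What is called first, only, known or untested is meant among the compounds shown, and "the series" means these compounds.

Compound 2 `Nc1nc(-c2cc(N3C[C@H](O)[C@@H](O)C3)ccc2O)cc(C2CCCCC2)n1` gives 800 nM in a functional assay on HCT-116 cells (Homo sapiens) for cytotoxicity, with a stated time of 48 h; on this read-out lower numbers stand for stronger inhibition of growth and higher numbers for weaker inhibition of growth. Compound 1 `CCc1cc(-c2cc(N3C[C@H](O)[C@@H](O)C3)ccc2O)nc(N)n1` gives 1000 nM; the step of a 1.3-fold lower number from compound 1 to compound 2 (0.10 log units; within the scatter) leaves the two compounds within the scatter of each other, so no order between them can be read. Compound 3 `Nc1nc(-c2cc(N3C[C@H](O)[C@@H](O)C3)ccc2O)cc(C2CCNCC2)n1` carries the change (piperidin-4-yl in place of cyclohexyl on an aromatic carbon). Within the data shown here, no measured step involves a change of this kind; the single step on record shows only that exchanging ethyl for cyclohexyl left the number unchanged within the scatter. With nothing to anchor a direction, a step of a 1.9-fold higher number from compound 2 to compound 3 (0.27 log units; within the scatter) is expected, and compound 3 is estimated at 1500 nM, within 400 nM to 6000 nM.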

Compound 3, concentration for 50% growth inhibition: > 10000 nM
Compound 3: a limit, no number (the forecaster's own chance of this, stated with the estimate: 5%); at least 6.6-fold (0.82 log units) between middle value and limit.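

Piperidin-4-yl in place of cyclohexyl gives an at least 12-fold higher number from compound 2 to compound 3 (1.09 log units; beyond the scatter), and in place of ethyl it gives an at least 10-fold higher number from compound 1 to compound 3 (1.00 log units; beyond the scatter). Until now, this position next to the ring nitrogen had shown no change in this assay, so a hetero atom in the six-membered ring is the first change here to move the read-out beyond the scatter. The value of compound 3 is a limit, not a number: the limit of > 10000 nM in this assay, at which 1 of the 3 values shown sits.

On these data alone, how far compound 3 lies past that limit stays open. Also open, as far as these compounds go, is whether the effect follows the ring amine specifically, which tetrahydropyran-4-yl or an acetyl group on the piperidine nitrogen would test.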